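Acetyl for Ethoxy on the Chain

This account rests on a few compounds, and the source may have more. Where it says the series, first, only, none or still open, it means among the compounds named here.

Of the compounds shown here, three sharing one core have been measured in a functional assay (trachea) with Cavia porcellus as the target (a higher number here means that more compound is needed for the effect, a lower number that less compound is needed), so far. Compound 1 (`CCCn1c(=O)n(CC(=O)O)c(=O)c2[nH]cnc21`) gives 41000 nM with a carboxy group on a saturated chain carbon bound to an aromatic nitrogen. Compound 2 (`CCCn1c(=O)n(CCO)c(=O)c2[nH]cnc21`) gives 510 nM with hydroxymethyl in that place, and compound 3 (`CCCn1c(=O)n(CCOCC)c(=O)c2[nH]cnc21`) gives 70 nM with ethoxymethyl there, the lowest number of the three. The two large steps are an 80-fold lower number from compound 1 to compound 2 (1.91 log units; beyond the scatter) and a 590-fold lower number from compound 1 to compound 3 (2.77 log units; beyond the scatter) and both start from the carboxy group, which compound 3 and compound 4 both lack. Compound 4 (`CCCn1c(=O)n(CCC(C)=O)c(=O)c2[nH]cnc21`) has not yet been measured. It carries acetyl in place of ethoxy on a saturated chain carbon, two bonds along the chain from an aromatic nitrogen. For the measured compounds named here, no measured step makes this exchange. The closest guide is the modest 7.3-fold lower number from compound 2 to compound 3 (0.86 log units; beyond the scatter) that came with ethyl in place of hydrogen on the oxygen, so changes at this chain end can register beyond the scatter. A small move towards a higher number seems likeliest, and the expected step is a 2.1-fold higher number from compound 3 to compound 4 (0.33 log units; beyond the scatter) in this assay for now. Compound 4 is estimated at 150 nM within an expected range from 50 nM to 500 nM when it is measured.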

Compound 4, half-maximal effective concentration: 3500 nM
For compound 4 the middle estimate is 23-fold (1.37 log units) below the measured one; measured number outside the range, above it.
By their numbers in this assay, from the lowest: compound 3; then compound 2; then compound 4; then compound 1.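

In this assay, acetyl in place of ethoxy brings a 50-fold higher number from compound 3 to compound 4 (1.70 log units; beyond the scatter) although both groups count 3 heavy atoms and the same hydrogen-bond donors and acceptors, so this chain end separates two groups that those counts do not tell apart. The earlier gain from ethyl on the oxygen therefore does not extend to every larger group at this place: acetyl in place of hydroxy brings a 6.9-fold higher number from compound 2 to compound 4 (0.84 log units; beyond the scatter) and leaves compound 4 on the higher side of compound 2, while 2-oxopropyl in place of carboxy still brings a 12-fold lower number from compound 1 to compound 4 (1.07 log units; beyond the scatter) and keeps compound 4 on the lower side of compound 1. Nothing available here gives a cause for these steps.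

The compounds shown leave open whether an amide, a methyl ester or a longer ether such as propoxy at this chain end would fall closer to compound 3 or to compound 4. They also leave open whether the gap between ethoxy and acetyl would persist with a butyl chain in place of the propyl chain on the shared core.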